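A tert-Butyl Tail in Place of 1-Methylpiperidin-4-yl

The compounds below may be only part of what the source reports. "The series", "measured", "known", "first", "only" and "open" are said of these compounds alone.

The series shares one core carrying a benzophenone-like ketone, and three members have been examined in an ADME assay on HL-60 cells (Homo sapiens) for cytotoxicity, read by resazurin assay, with a stated time of 72 h; a lower number here means that less compound is needed, a higher number that more compound is needed for the effect. Compound 1 `O=C(c1ccccc1)c1ccc2nc(NCCC3CCCNC3)[nH]c2c1` reaches only the limit of the assay, giving > 30000 nM in this assay. Compound 2 `O=C(NCCC1CCNCC1)Nc1nc2ccc(C(=O)c3ccccc3)cc2[nH]1` likewise stops at the limit, with > 30000 nM in this assay. Compound 3 `CN1CCC(Cn2c(N)nc3ccc(C(=O)c4ccccc4)cc32)CC1` also returns a limit rather than a number, > 30000 nM in this assay. Compound 3 thus stands where the whole set stands: at the limit of > 30000 nM in this assay, at which 3 of the 3 values shown sit, so no ordering among the three can be drawn and none is claimed.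

Compound 4 `CC(C)(C)Cn1c(N)nc2ccc(C(=O)c3ccccc3)cc21` has not yet been measured in this assay. It differs from compound 3 by tert-butyl in place of 1-methylpiperidin-4-yl on a saturated chain carbon bound to an aromatic nitrogen; cut one bond further out, the same change reads (1-methylpiperidin-4-yl)methyl to neopentyl. Within the data shown here, because every value so far sits at the limit of > 30000 nM in this assay, at which 3 of the 3 values shown sit, there is no measured step from which a direction could be read, and the step from compound 3 to compound 4 is expected to be none beyond the usual scatter, a step that the limit leaves unreadable from compound 3 to compound 4. Compound 4 is therefore estimated to give 40000 nM in this assay, with a range from 15000 nM to 100000 nM, most likely again as a limit rather than a number.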

Compound 4, half-maximal effective concentration: > 30000 nM
Compound 4: a limit, no number (the forecaster's own chance of this, stated with the estimate: 80%); the middle value does not contradict the limit.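

In this assay compound 4 gives > 30000 nM as a limit and not a number. Compound 3 also stands at a limit, so no step can be read between compound 3 and compound 4. What the compounds shown leave open is whether any of them differs from another, as the whole set sits at one limit: the limit of > 30000 nM in this assay, at which 4 of the 4 values shown sit.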